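From a Urea to a Spirocyclic Amide at the Carbonyl

A few compounds are considered here, and "the series" means these few. Any claim that something is new, unique, unknown or untested is made for them only; others in the source may bear on it.

The shared core of compound 1 `O=C(N1CCCCC1)N1CC(c2nc(-c3cccc(Cl)c3)no2)C1` carries a piperidin-1-yl group on its carbonyl carbon. In an assay on HEK293 cells for negative allosteric modulation of metabotropic glutamate receptor 5 (Homo sapiens), read by FLIPR (a higher number here means a weaker inhibitor, a lower number a stronger inhibitor), compound 1 gives only a limit, > 10000 nM. Compound 2 `O=C(C1CCC(C(F)(F)F)CC1)N1CC(c2nc(-c3cccc(F)c3)no2)C1` also reaches only the limit, > 10000 nM. Compound 3 `Cc1cccc(-c2noc(C3CN(C(=O)C4CCC(C(F)(F)F)CC4)C3)n2)c1` likewise gives only the limit, > 10000 nM. Within the data shown here, the one step that can be traced, a step that the two limits leave unreadable from compound 2 to compound 3, is therefore of unreadable size, and every value shown sits at the limit of > 10000 nM in this assay, at which 3 of the 3 values shown sit.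

Compound 4 `O=C(C1CCC2(CCC2)CC1)N1CC(c2nc(-c3cccc(Cl)c3)no2)C1` is not yet measured. It differs from compound 1 by a group of 9 heavy atoms (9 carbon; one four-membered non-aromatic ring of carbon only, one six-membered non-aromatic ring of carbon only) in place of a group of 6 heavy atoms (5 carbon, 1 nitrogen; one six-membered non-aromatic ring with 1 hetero atom), on a carbonyl carbon. Among the measured compounds shown here, no measured step touches this change directly: compound 2 and compound 3, which carry a six-membered non-aromatic ring of carbon only on the carbonyl carbon, remain at the limit, as does compound 1 with its piperidin-1-yl group. No step beyond the scatter is therefore expected in this assay. The expected step of a number no higher from compound 1 to compound 4 (the limit leaves the size open) is close to none. Compound 4 is estimated at 10000 nM, between 2000 nM and 40000 nM, and is most likely again reported only as a limit.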

Compound 4, half-maximal inhibitory concentration: > 10000 nM
Compound 4 ended at the assay's limit; the forecaster's own chance of this, stated with the estimate: 70%; the middle value sits exactly at the limit.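

Compound 1 and compound 4 both give only a limit in this assay, so no step can be read between them. The compounds shown leave open whether any group on the carbonyl carbon gives a measurable value in this assay, for all stand at one limit: the limit of > 10000 nM in this assay, at which 4 of the 4 values shown sit.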